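Chloromethyl in Place of Formyl on the Shared Core

This account rests on a few compounds, and the source may have more. Where it says the series, first, only, none or still open, it means among the compounds named here.

Compound 1 `O=Cc1ccc(-c2cnc(C(=O)CCCCCCc3ccccc3)o2)nc1` carries a formyl group on a six-membered aromatic ring with one nitrogen, and in an assay for inhibition of Fatty-acid amide hydrolase 1 (Rattus norvegicus), using a Dixon plot (a higher number here means a weaker inhibitor, a lower number a stronger inhibitor), compound 1 gives 2.2 nM. Among the three compounds measured, this is the lowest number. The nearest is compound 3 `O=C(CCCCCCc1ccccc1)c1ncc(-c2ccc(CO)cn2)o1`, which bears a hydroxymethyl group in the same place and in this assay gives 3.2 nM. The furthest is compound 2 `COCOCc1ccc(-c2cnc(C(=O)CCCCCCc3ccccc3)o2)nc1`, which bears a (methoxymethoxy)methyl group and in this assay gives 10.1 nM.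

The new compound, compound 4 `O=C(CCCCCCc1ccccc1)c1ncc(-c2ccc(CCl)cn2)o1`, differs from compound 1 in one place: chloromethyl in place of formyl on an aromatic carbon.

For the measured compounds named here, two measured steps bear on this change. The step of a 1.5-fold higher number from compound 1 to compound 3 (0.16 log units; within the scatter) shows that swapping the formyl group for a hydroxymethyl group changes little, while the step of a 4.6-fold higher number from compound 1 to compound 2 (0.66 log units; beyond the scatter) shows that a larger group in this place weakens inhibition modestly; the step of a 3.2-fold lower number from compound 2 to compound 3 (0.50 log units; beyond the scatter) points the same way. Going by the values given here, no measured compound carries a chloromethyl group, so its effect is not known directly.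

Compound 4 is therefore expected to inhibit a little less strongly than compound 1, a step of a 2.3-fold higher number from compound 1 to compound 4 (0.36 log units; beyond the scatter).

For compound 4 the estimate is 5 nM, with a range from 2 nM to 15 nM.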

Compound 4, inhibition constant: 22.4 nM
Compound 4: middle estimate off by 4.5-fold (0.65 log units), on the low side; measured number above the stated range.
By their numbers in this assay, from the lowest: compounds 1 and 3 (each within the scatter of the next); then compound 2; then compound 4.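

The earlier compounds shown here suggested that only a larger group costs anything at this position, but chloromethyl has the same count of heavy atoms as the formyl group it replaces, and in this assay the change is still large (a 10-fold higher number from compound 1 to compound 4 (1.01 log units; beyond the scatter)). Size alone therefore does not order these compounds, since the small chloromethyl group also gives a higher number than the bulkier (methoxymethoxy)methyl group (a 2.2-fold higher number from compound 2 to compound 4 (0.35 log units; beyond the scatter)), and exchanging only the hydroxy for chloro on the same saturated carbon accounts for a clear loss (a 7.0-fold higher number from compound 3 to compound 4 (0.85 log units; beyond the scatter)). Compound 4 is also the only one of the four whose group here contains no oxygen, although nothing available explains the loss of inhibition, and this link remains only an observation across four compounds.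

On these data alone, it remains open whether the chlorine itself raises the number or whether the missing oxygen does. A plain methyl group, a fluoromethyl group, an aminomethyl group or a carboxylic acid at this position would help to separate these two readings.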